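The source may hold more compounds than are shown below. What is called first, only, known or untested is meant among the compounds shown, and "the series" means these compounds.

Measured so far in a functional assay for inhibition, with Homo sapiens as the target; a higher number here means weaker binding, a lower number tighter binding:
compound 1 `O=C(O)CC/C=C\CC1COC(c2ccc(C(F)(F)F)cc2)OC1c1cccnc1`: 1780 nM
compound 2 `O=C(O)CC/C=C\CC1COC(c2cccc3ccccc23)OC1c1cccnc1`: 631 nM
compound 3 `COc1ccc(OC(C)(C)C2OCC(C/C=C\CCC(=O)O)C(c3cccnc3)O2)cc1`: 302 nM

Compound 3, at 302 nM, has the lowest number of the three in this assay, and its gaps to compound 2 and compound 1 both lie beyond the scatter. The compound now awaiting measurement is compound 4 `COc1ccccc1OC(C)(C)C1OCC(C/C=C\CCC(=O)O)C(c2cccnc2)O1`, which keeps everything else in compound 3 and changes only where the methoxy group sits on the outer aromatic ring: 2-methoxyphenyl in place of 4-methoxyphenyl on an oxygen on a saturated carbon.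

Among the measured compounds shown here, only one measured step offers any guide, and it is an indirect one: a 2.8-fold lower number from compound 1 to compound 2 (0.45 log units; beyond the scatter). That modest step exchanges one whole group for another, whereas compound 4 differs from compound 3 only in the position of the methoxy group. No measured pair among these compounds shows what such a shift does, so the data give no direction for it. A step smaller than that modest one is therefore expected, quite possibly none beyond the scatter, and the expectation stays close to compound 3 at 302 nM. The expected change is a 1.1-fold lower number from compound 3 to compound 4 (0.03 log units; within the scatter). For compound 4 the estimated value is 280 nM, with an expected range from 100 nM to 750 nM.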

Compound 4, dissociation constant: 224 nM
Compound 4: the middle estimate sits 1.3-fold (0.10 log units) above what was measured; the range from low to high includes it.
By their numbers in this assay, from the lowest: compounds 4 and 3 (each within the scatter of the next); then compound 2; then compound 1.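

In this assay, moving the methoxy group around the outer aromatic ring gives a 1.3-fold lower number from compound 3 to compound 4 (0.13 log units; within the scatter), so 2-methoxyphenyl and 4-methoxyphenyl, each on an oxygen on a saturated carbon, cannot be told apart by this read-out. Among the compounds shown here, this is the first measured pair here that tests the position of a group while keeping the same atoms, and the step stays within the scatter, whereas the exchange of one whole group for another in a 2.8-fold lower number from compound 1 to compound 2 (0.45 log units; beyond the scatter) lies beyond it. Nothing at hand offers an explanation of this result.

As far as these compounds go, the two methoxy positions measured here say nothing about what a different group on the outer aromatic ring would do, so it remains open whether an ethoxy group, a chlorine atom or a plain phenyl ring would stay within the scatter of these two compounds. From the compounds shown here alone, it is equally open how the number in this assay would respond if the two methyl groups on the saturated carbon gave way to a cyclopropane ring, or if a tetrazole took the place of the carboxylic acid at the end of the chain.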